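Working notes: a third analogue for the assay at a single concentration

A few compounds are considered here, and "the series" means these few. Any claim that something is new, unique, unknown or untested is made for them only; others in the source may bear on it.

Compound 1 `CN(C)C(=O)Cc1sc(NC(=O)C2COc3ccccc3O2)nc1-c1ccncc1`: 56.9%
Compound 2 `CN(C)C(=O)Cc1sc(NC(=O)c2ccncc2)nc1-c1ccncc1`: 38.1%

Both values come from an assay on isolated protein for inhibition of Rho-associated protein kinase 2 (Homo sapiens), read by ELISA, with a stated time of 30 min, tested at 10 uM, in the presence of a further agent that is not named here; on this read-out higher numbers stand for more inhibition at the one concentration tested (going by the name of the read-out) and lower numbers for less inhibition. Going by the values given here, compound 2 stands lowest of the two numbers; the one measured step, a number 18.8 percentage points lower from compound 1 to compound 2 (beyond the scatter), concerns pyridin-4-yl in place of 2,3-dihydro-1,4-benzodioxin-2-yl on a carbonyl carbon. Compound 3 `O=C(Nc1nc(-c2ccncc2)c(CN2CCCC2)s1)c1ccncc1` differs from compound 2 by pyrrolidin-1-yl in place of dimethylcarbamoyl on a saturated chain carbon bound to an aromatic carbon. Among the compounds with values here, no measured step touches that position, so nothing here supports a step beyond the scatter in either direction. For compound 3 the expected value is therefore 38%, with a wide range from 15% to 62%. The step of a number 0.1 percentage points lower from compound 2 to compound 3 (within the scatter) is expected to stay within the scatter.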

Compound 3, a percentage reported as inhibition, at one concentration (the size of the read-out at that concentration, not a potency): 47.6%
Estimate against measurement, compound 3: 9.6 percentage points below; the measured number falls inside the stated range.
By their numbers in this assay, from the lowest: compounds 2, 3 and 1 (each within the scatter of the next, the first and the last beyond it).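

At this position, on a saturated chain carbon bound to an aromatic carbon, pyrrolidin-1-yl in place of dimethylcarbamoyl gives a number 9.5 percentage points higher from compound 2 to compound 3 (within the scatter) in this assay. For this one pair, a ring with no carbonyl can therefore stand where the open amide stood without a step beyond the scatter. Nothing available explains this result.

Open, on these data alone, is how a morpholine, a carboxylic acid or a longer chain at this place would read. Also open, as far as these compounds go, is whether the same change holds with 2,3-dihydro-1,4-benzodioxin-2-yl on the carbonyl carbon.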